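Furan in place of ethynyl on the shared core

The source may hold more compounds than are shown below. What is called first, only, known or untested is meant among the compounds shown, and "the series" means these compounds.

Compound 2 `C#Cc1cn([C@@H]2O[C@H](CO)[C@@H](O)[C@H]2O)c2nc(N)nc(OC)c12` in a functional assay on HepG2 cells (Homo sapiens) for antiproliferative activity, read by XTT assay, with a stated time of 72 h (on this read-out higher numbers stand for weaker inhibition and lower numbers for stronger inhibition), gives only a limit, > 20000 nM. Compound 1 `COc1nc(N)nc2c1c(-c1ccccc1)cn2[C@@H]1O[C@H](CO)[C@@H](O)[C@H]1O` likewise returns a limit, > 20000 nM. The change from phenyl to ethynyl therefore gives a step that the two limits leave unreadable from compound 1 to compound 2. Compound 3 `C#Cc1cn([C@@H]2O[C@H](CO)[C@@H](O)[C@H]2O)c2ncnc(OC)c12` gives 12700 nM, and removing the amino group gives an at least 1.5-fold lower number from compound 2 to compound 3 (0.19 log units; that floor lies within the scatter). Compound 4 `COc1nc(N)nc2c1c(-c1ccco1)cn2[C@@H]1O[C@H](CO)[C@@H](O)[C@H]1O` differs from compound 2 by furan-2-yl in place of ethynyl on an aromatic carbon. Among the compounds with values here, the only step at this aromatic carbon, from phenyl to ethynyl, cannot be read, since both sit at the limit of > 20000 nM in this assay, at which 2 of the 3 values shown sit. Within the data shown here, no measured step supports movement beyond the scatter, so compound 4 is expected to remain near that limit. Compound 4 is estimated at 30000 nM, from 10000 nM to 100000 nM. The expected step that the limit leaves unreadable from compound 2 to compound 4 is thus none beyond the scatter.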

Compound 4, half-maximal inhibitory concentration: > 20000 nM
Compound 4: a limit, no number; the forecaster's own chance of this, stated with the estimate: 75%; the middle value does not contradict the limit.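

In this assay compound 4 gives only a limit, > 20000 nM, so its steps from compound 1 and compound 2 cannot be read: the limit of > 20000 nM in this assay, at which 3 of the 4 values shown sit. From the compounds shown here alone, how furan-2-yl, phenyl and ethynyl compare at this aromatic carbon stays open.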